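The source may report more compounds than this note shows. Statements on the series, on what has been measured and on what is new or still open speak of the compounds shown alone.

The measured compounds are compound 1 `CC(C)=CCC1Cc2c(OCCCNS(=O)(=O)c3ccc(C(F)(F)F)cc3)cc(=O)n(CCCO)c2CC1(C)C` with 0%, compound 2 `CC(C)=CCC/C(C)=C/CC1Cc2c(OCC=C(C)C)cc(=O)n(CCCO)c2CC1(C)C` with 15.9%, and compound 3 `CC(C)=CCC/C(C)=C/COc1cc(=O)n(CCCO)c2c1CC(C/C=C(\C)CCC=C(C)C)C(C)(C)C2` with 3.1%, all in a functional assay on PANC-1 cells (Homo sapiens) for inhibition, read by MTT assay, with a stated time of 24 h, tested at 10 uM; on this read-out higher numbers stand for more inhibition at the one concentration tested (going by the name of the read-out) and lower numbers for less inhibition.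

Compound 4 `CC(C)=CCC/C(C)=C/CC1Cc2c(OCCCNS(=O)(=O)c3ccc(C(F)(F)F)cc3)cc(=O)n(CCCO)c2CC1(C)C` has not yet been measured in this assay. It differs from compound 1 by 3-methylbut-2-en-1-yl in place of hydrogen on a saturated chain carbon bound to a double-bonded chain carbon. The same change is seen between two measured compounds: compound 3 differs from compound 2 by 3-methylbut-2-en-1-yl in place of hydrogen on a saturated chain carbon bound to a double-bonded chain carbon, and that step gave a number 12.8 percentage points lower from compound 2 to compound 3 (beyond the scatter). The difference between the cores of compound 1 and compound 2 is not broken down here. Compound 1 already sits at the bottom of the scale with 0%, so a downward step of the earlier size has no room to appear. Compound 4 is therefore expected to give about 2%, a step of a number 2 percentage points higher from compound 1 to compound 4 (within the scatter), because compound 1 gives 0% and the change lowered a number 12.8 percentage points lower from compound 2 to compound 3 (beyond the scatter) once before. The expected range runs from 0% to 12%.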

Compound 4, a percentage reported as inhibition, at one concentration (the size of the read-out at that concentration, not a potency): 0%
The estimate for compound 4 lay 2 percentage points above the measured number; the measured number falls inside the stated range.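

In this assay, 3-methylbut-2-en-1-yl in place of hydrogen on a saturated chain carbon bound to a double-bonded chain carbon gave no change at the digits printed from compound 1 to compound 4 (within the scatter). Set beside the earlier case, the two steps cannot be told apart: the same change on two cores in this assay, a number 12.8 percentage points lower (beyond the scatter) from compound 2 to compound 3 and no change at the digits printed (within the scatter) from compound 1 to compound 4, 12.8 percentage points apart, within the scatter of two such steps

Compound 1 gives 0%, the bottom of the scale, and a downward step has no room to appear there; the pair neither confirms nor rules out that the change carries over from one core to another at the same size.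

The compounds shown leave open how the change behaves on further cores that read clearly above the bottom of the scale. They also leave open what a carboxylic acid or an amine would do at this place.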